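A few compounds are considered here, and "the series" means these few. Any claim that something is new, unique, unknown or untested is made for them only; others in the source may bear on it.

Measured compounds in an ADME assay on BJ cells (Homo sapiens) for cytotoxicity, with a stated time of 72 h; a higher number here means that more compound is needed for the effect, a lower number that less compound is needed:
compound 1, `C=C[C@@](C)(/C=C/c1ccc(Nc2ccc(OC)c(F)c2)cc1)CCC=C(C)C`: > 36600 nM
compound 2, `C=C[C@@](C)(/C=C/c1ccc(Nc2ccc(F)c(F)c2)cc1)CCC=C(C)C`: > 36600 nM
compound 3, `C=C[C@@](C)(/C=C/c1ccc(Nc2cc(F)c(F)cc2F)cc1)CCC=C(C)C`: > 36600 nM

Each of these three values is a limit of this assay, not a number. Compound 2 stands at that limit, as do the two other values shown (the limit of > 36600 nM in this assay, at which 3 of the 3 values shown sit). The measured steps a step that the two limits leave unreadable from compound 1 to compound 2, a step that the two limits leave unreadable from compound 1 to compound 3 and a step that the two limits leave unreadable from compound 2 to compound 3 therefore cannot be read, because both ends of each sit at the limit (the limit of > 36600 nM in this assay, at which 3 of the 3 values shown sit).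

Compound 4, `C=C[C@@](C)(/C=C/c1ccc(-c2cccc(Br)c2)cc1)CCC=C(C)C`, is not yet measured. The change from compound 2 is 3-bromophenyl in place of (3,4-difluorophenyl)amino on an aromatic carbon. For the measured compounds named here, none of the measured steps bears on this part of the molecule; they alter only fluoro and methoxy substituents on the ring attached to the nitrogen, and all are unreadable. No step size can thus be derived for this change, and the expectation is that the step that the limit leaves unreadable from compound 2 to compound 4 stays unreadable, with compound 4 again most likely reported as a limit. On that basis compound 4 is estimated at 40000 nM, within a range of 15000 nM to 100000 nM in this assay.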

Compound 4, half-maximal effective concentration: > 36600 nM
Compound 4 gave a limit, no number; the forecaster's own chance of this, stated with the estimate: 75%; the middle value is on the limit's open side.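

Compound 4 also returns only a limit in this assay, not a number: > 36600 nM. The change from compound 2 to compound 4 therefore gives no readable step, because both ends sit at the limit: the limit of > 36600 nM in this assay, at which 4 of the 4 values shown sit. The compounds shown leave open whether any of these changes shifts the half-maximal effective concentration at all.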